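Replacing the aryl group of compound 3

The source may report more compounds than this note shows. Statements on the series, on what has been measured and on what is new or still open speak of the compounds shown alone.

Measured in a functional assay on the whole organism (Hindlimb, strain albino) with Mus musculus as the target, in the maximal electroshock model, with a stated time of 0.5 h; a higher number here means that more compound is needed for the effect, a lower number that less compound is needed:
Compound 1 `CC(=O)N1N=C(Nc2nc3ccc(C)cc3s2)CC1c1ccc(O)cc1` gives 50.2 umol/kg
Compound 2 `CC(=O)N1N=C(Nc2nc3ccccc3s2)CC1c1ccccc1` gives 315 umol/kg
Compound 3 `COc1ccc(C2CC(Nc3nc4ccccc4s3)=NN2C(C)=O)cc1O` gives 259 umol/kg

Compound 3 at 259 umol/kg lies within the scatter of compound 2 at 315 umol/kg and both stand clearly above compound 1 at 50.2 umol/kg on this scale. Within the data shown here, the compound to come is compound 4 `CC(=O)N1N=C(Nc2nc3ccccc3s2)CC1c1ccc(O)cc1` and it has 4-hydroxyphenyl in place of 3-hydroxy-4-methoxyphenyl on a saturated ring carbon as its one change from compound 3. Among the measured compounds shown here, the only measured step at this place is a 1.2-fold lower number from compound 2 to compound 3 (0.09 log units; within the scatter) and it shows little response to the aryl group so far. Compound 1 carries the same 4-hydroxyphenyl and gives 50.2 umol/kg but it also has an extra methyl group on the core. For the measured compounds named here, no measured pair separates these two differences, so only part of that gap can be expected to carry over. The expected step is therefore a moderate one towards a lower number in this assay and is estimated as a 2.2-fold lower number from compound 3 to compound 4 (0.33 log units; beyond the scatter) for this change. For compound 4 the estimate is 120 umol/kg and 45 umol/kg to 300 umol/kg is the expected range.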

Compound 4, dose for half-maximal effect: 249 umol/kg
Compound 4: the middle estimate sits 2.1-fold (0.32 log units) below what was measured, within the range that was stated.
By their numbers in this assay, from the lowest: compound 1; then compounds 4, 3 and 2 (each within the scatter of the next).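

In this assay, the aryl group on the saturated ring carbon makes no readable difference: the result is a 1.0-fold lower number from compound 3 to compound 4 (0.02 log units; within the scatter) and a 1.3-fold lower number from compound 2 to compound 4 (0.10 log units; within the scatter), so phenyl, 3-hydroxy-4-methoxyphenyl and 4-hydroxyphenyl cannot be told apart here. Among these compounds, the gap to compound 1 therefore belongs to the methyl on an aromatic carbon of the core, with a 5.0-fold higher number from compound 1 to compound 4 (0.70 log units; beyond the scatter) for hydrogen in place of methyl, and this is the only one-place step so far that lies beyond the scatter. Nothing given here explains why this methyl matters.

On these data alone, whether the methyl has the same effect alongside phenyl or 3-hydroxy-4-methoxyphenyl remains open. Also open, as far as these compounds go, is whether a chlorine or an amine on the aryl ring, or a longer chain in place of the acetyl group, would change the number at all.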